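The source may hold more compounds than are shown below. What is called first, only, known or untested is meant among the compounds shown, and "the series" means these compounds.

Within the data shown here, in an assay on CHO cells for displacement of a labelled ligand from adenosine receptor A3 (Homo sapiens) (on this read-out lower numbers stand for stronger inhibition and higher numbers for weaker inhibition), compound 2 `O=C(NC1CC1)[C@H]1O[C@@H](n2cnc3c(NCc4cccc(I)c4)nc(Cl)nc32)[C@H](O)[C@@H]1O` gives 2.95 nM, which sits within the scatter of the only other number, that of compound 1 `O=C(NC1CC1)[C@H]1O[C@@H](n2cnc3c(NC4CC4)nc(Cl)nc32)[C@H](O)[C@@H]1O`, which gives 5.62 nM. Among the measured compounds shown here, the single step measured so far, a 1.9-fold lower number from compound 1 to compound 2 (0.28 log units; within the scatter), swapped cyclopropyl for a benzyl on a nitrogen on an aromatic ring. Compound 3 `O=C(NCc1cccc(C(F)(F)F)c1)[C@H]1O[C@@H](n2cnc3c(NCc4cccc(I)c4)nc(Cl)nc32)[C@H](O)[C@@H]1O` differs from compound 2 by 3-(trifluoromethyl)benzyl in place of cyclopropyl on an amide-type nitrogen. For the measured compounds named here, no measured step touches that amide-type nitrogen, so the one known step offers only a loose guide. Compound 3 is nevertheless expected to give a higher number, a 10-fold higher number from compound 2 to compound 3 (1.01 log units; beyond the scatter), estimated at 30 nM with a range from 5 nM to 200 nM.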

Compound 3, inhibition constant: 355 nM
Compound 3: the middle estimate sits 12-fold (1.07 log units) below what was measured; measured number above the stated range.
By their numbers in this assay, from the lowest: compounds 2 and 1 (each within the scatter of the next); then compound 3.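

In this assay, putting 3-(trifluoromethyl)benzyl in place of cyclopropyl on the amide-type nitrogen brings a 120-fold higher number from compound 2 to compound 3 (2.08 log units; beyond the scatter), a large step. The earlier swap of cyclopropyl on the nitrogen on an aromatic ring, a 1.9-fold lower number from compound 1 to compound 2 (0.28 log units; within the scatter), stayed within the scatter, so the two nitrogens do not respond alike to these benzyl groups in the compounds shown. No measurement given here accounts for the rise. Still open, on these data alone, is whether plain benzyl on the amide-type nitrogen behaves like 3-(trifluoromethyl)benzyl, and whether a methyl or ethyl group there keeps the number near that of compound 2.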